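Acetamido in Place of Methoxy on the Shared Core

The source may report more compounds than this note shows. Statements on the series, on what has been measured and on what is new or still open speak of the compounds shown alone.

Compound 3, `CCC(COc1cccc(OC)c1)OC(=O)NCc1ccccc1`, carries a methoxy group on the aromatic ring of the shared core. In an assay for inhibition of zeta-carotene desaturase, chloroplastic/chromoplastic (Capsicum annuum), using a Dixon plot, with a stated time of 8 h (on this read-out lower numbers stand for stronger inhibition and higher numbers for weaker inhibition), compound 3 gives only a limit, > 100000 nM, and not a number. Compound 1, `CCC(COc1cccc(Cl)c1)OC(=O)NCc1ccccc1`, likewise reaches only a limit, > 100000 nM. Compound 2, `CCC(COc1cccc(C(C)C)c1)OC(=O)NCc1ccccc1`, also stops at a limit, > 100000 nM. The steps a step that the two limits leave unreadable from compound 1 to compound 2, a step that the two limits leave unreadable from compound 1 to compound 3 and a step that the two limits leave unreadable from compound 2 to compound 3 are all unreadable, since every value sits at the limit of > 100000 nM in this assay, at which 3 of the 3 values shown sit. Compound 4, `CCC(COc1cccc(NC(C)=O)c1)OC(=O)NCc1ccccc1`, differs from compound 3 by acetamido in place of methoxy on an aromatic carbon. Among the measured compounds shown here, no measured step informs the size of this change, and none of the ring substituents seen so far moves the read-out off the limit. Compound 4 is therefore expected to stay close to that limit, with an estimated step of a number no higher from compound 3 to compound 4 (the limit leaves the size open). The value expected for compound 4 is 100000 nM, within a range from 30000 nM to 300000 nM.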

Compound 4, half-maximal inhibitory concentration: > 100000 nM
Compound 4 ended at the assay's limit (the forecaster's own chance of this, stated with the estimate: 85%); the middle value lies on the limit itself.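

The limit reached by compound 4 leaves its steps from compound 1, compound 2 and compound 3 unreadable, so no new step can be read: the limit of > 100000 nM in this assay, at which 4 of the 4 values shown sit.

The compounds shown leave open whether any substituent on the aromatic ring of the shared core moves the read-out off this limit, and by how much.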